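The source may report more compounds than this note shows. Statements on the series, on what has been measured and on what is new or still open speak of the compounds shown alone.

Measured so far:
compound 1, `Cc1cccc(-c2ccc(C(O)CCCCCO)cc2)c1`: > 100000 nM
compound 2, `OCCCCCC(O)c1ccc(-c2cccc(Cl)c2)cc1`: > 100000 nM
compound 3, `Cc1cc(F)ccc1-c1ccc(C(=O)CCCCCO)cc1`: 20000 nM

In a functional assay on J774 cells (Mus musculus) for cytotoxicity, read by resazurin assay (on this read-out higher numbers stand for weaker inhibition and lower numbers for stronger inhibition), compound 1 gives > 100000 nM, which is a limit of the assay and not a number. Compound 2 likewise gives > 100000 nM, again a limit. The change between them is chloro in place of methyl on an aromatic carbon, and the step it made is a step that the two limits leave unreadable from compound 1 to compound 2; both values sit at the limit of > 100000 nM in this assay, at which 2 of the 3 values shown sit, so the size of this step cannot be read. Compound 3 is the only one of the three with a number: in this assay compound 3 gives 20000 nM. The difference between the core of compound 1 and the core of compound 3 is not broken down here.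

Compound 4, `O=C(CCCCCO)c1ccc(-c2ccc(F)cc2Cl)cc1`, has not yet been measured. It differs from compound 3 by chloro in place of methyl on an aromatic carbon. Within the data shown here, this is the same kind of change as the one from compound 1 to compound 2, but the surroundings are not the same: in compound 2 the chloro sits meta to a large group, whereas in compound 4 it sits ortho to a large group and meta to a fluoro group.

Since the earlier step is unreadable, the expectation for compound 4 rests on compound 3 alone and on the small size of the swapped groups. Compound 4 is expected to differ from compound 3 by a step of no change at the digits printed from compound 3 to compound 4 (within the scatter). Compound 4 is estimated at 20000 nM, with a likely range from 7000 nM to 60000 nM.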

Compound 4, half-maximal inhibitory concentration: 15000 nM
For compound 4 the middle estimate is 1.3-fold (0.12 log units) above the measured one; measured number inside the range.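

In this assay, chloro in place of methyl on an aromatic carbon gives a 1.3-fold lower number from compound 3 to compound 4 (0.12 log units; within the scatter), so on this core the two groups cannot be told apart in the values shown. The same change on the core of compound 1 gives no size to set beside this one, because compound 1 and compound 2 each sit at a limit of the assay and not at a number: the limit of > 100000 nM in this assay, at which 2 of the 4 values shown sit. The change therefore has one readable step and one unreadable step, which shows neither that it carries over from one core to the other nor that it behaves differently there, and this single readable pair says nothing about the same swap at any other place on the ring.

Still open, on these data alone, is how this assay would respond to a different group at the same place, such as a nitrile or a trifluoromethyl, or to a carboxylic acid, an amine or a longer chain in place of the present chain. Also open is whether the lack of a step beyond the scatter would hold in any read-out other than this assay, since these compounds are shown in this one alone.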